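The source may report more compounds than this note shows. Statements on the series, on what has been measured and on what is new or still open speak of the compounds shown alone.

Measured in an assay on HEK293 cells for antagonist activity at transient receptor potential cation channel subfamily V member 2 (Rattus norvegicus), read by fluorescence and calcium flux, with a stated time of 5 min; on this read-out higher numbers stand for weaker inhibition and lower numbers for stronger inhibition:
compound 1, `CCCCCCCC/C=C\CCCCCCCCCCCC(=O)NCc1ccc(O)c(OC)c1`: 490 nM
compound 2, `CCCCCCCCCCCCCCCC(=O)NCc1ccc(O)c(OC)c1`: > 10000 nM
compound 3, `CCCCCCCCCCCCCCCC[Se]CCC(=O)NCc1ccc(O)c(OC)c1`: 4300 nM

The value for compound 2 is a limit of the assay and not a number (the limit of > 10000 nM in this assay, at which 1 of the 3 values shown sits); compound 2 thus stands at the weak end of what has been measured here. Compound 4, `CCCCCCCCCCCCCCCCCCCC(=O)NCc1ccc(O)c(OC)c1`, has not been measured in this assay. Relative to compound 2 the change is butyl in place of hydrogen on a saturated chain carbon, ten or more bonds along the chain from a carbonyl carbon.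

Among the measured compounds shown here, one measured step bears on it: an at least 20-fold higher number from compound 1 to compound 2 (1.30 log units; beyond the scatter). That step removed chain length together with the double bond and gave the weakest result of the series, so restoring chain length, as in compound 4, points toward a lower number. The chain of compound 4 stays saturated, however, so the full return to the number of compound 1 is not expected. Compound 3 shows that a long chain can give a measurable number rather than a limit, at 4300 nM.

Compound 4 is therefore expected to give a step of an at least 1.6-fold lower number from compound 2 to compound 4 (0.22 log units; that floor lies within the scatter), with the estimate 6000 nM and a range of 1500 nM to 20000 nM, and a real chance that only a limit is reported again.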

Compound 4, half-maximal inhibitory concentration: 3100 nM
Estimate against measurement, compound 4: 1.9-fold (0.29 log units) above; low and high end bracket the measured number.
By their numbers in this assay, from the lowest: compound 1; then compounds 4 and 3 (each within the scatter of the next). At a limit, above all of these: compound 2.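

In this assay, butyl in place of hydrogen on a saturated chain carbon, ten or more bonds along the chain from a carbonyl carbon, gives an at least 3.2-fold lower number from compound 2 to compound 4 (0.50 log units; beyond the scatter), so lengthening the saturated chain alone is enough to bring a measurable number. Compound 2 itself stands at a limit and not at a number, so this step has only a floor: the limit of > 10000 nM in this assay, at which 1 of the 4 values shown sits. Lengthening does not close the whole gap, since octyl in place of dec-1-en-1-yl still gives a 6.3-fold higher number from compound 1 to compound 4 (0.80 log units; beyond the scatter), a step that changes chain length and the double bond together and so does not separate the two.

On these data alone, whether a longer saturated chain would lower the number further remains open. Also open, as far as these compounds go, is how a double bond placed in the chain of compound 4, or a carboxylic acid or an amine at the chain end, would read here.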